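The compounds below may be only part of what the source reports. "The series", "measured", "known", "first", "only" and "open" are said of these compounds alone.

Measured in a functional assay on T29Kt1 cells (Homo sapiens) for cytotoxicity, read by sulforhodamine B assay, with a stated time of 3 days; on this read-out higher numbers stand for weaker inhibition and lower numbers for stronger inhibition:
- Compound 1 `OCc1cn(Cc2ccc(Cl)cc2)c2ccccc12`: 79 nM
- Compound 2 `O=[N+]([O-])c1ccc(Cn2cc(CO)c3ccccc32)cc1`: 150 nM
- Compound 3 `COc1ccc2c(c1)c(CO)cn2Cc1ccc(Cl)cc1`: 12500 nM

Compound 1 sits at the low end of these numbers, and compound 2 stays close to it, with a 1.9-fold higher number from compound 1 to compound 2 (0.28 log units; within the scatter). Compound 4 `Cc1cn(Cc2ccc(Cl)cc2)c2ccccc12` differs from compound 1 by hydrogen in place of hydroxy on a saturated chain carbon bound to an aromatic carbon, or hydroxymethyl to methyl.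

Among the compounds with values here, no measured compound lacks the hydroxy, so the two known steps offer only indirect guidance. Nitro in place of chloro on an aromatic carbon gave the small step above, while methoxy in place of hydrogen on an aromatic carbon gave a 160-fold higher number from compound 1 to compound 3 (2.20 log units; beyond the scatter). That large step shows that one change can move the numbers in this assay far, so a step beyond the scatter toward a higher number is expected, though its size is uncertain. The expected step is a 10-fold higher number from compound 1 to compound 4 (1.01 log units; beyond the scatter). Compound 4 is estimated at 800 nM, with an expected range from 80 nM to 12000 nM.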

Compound 4, half-maximal inhibitory concentration: > 31600 nM
Compound 4: a limit, no number; the forecaster's own chance of this, stated with the estimate: 10%; at least 39-fold (1.59 log units) between middle value and limit.
By their numbers in this assay, from the lowest: compounds 1 and 2 (each within the scatter of the next); then compound 3. At a limit, above all of these: compound 4.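

Replacing the hydroxymethyl with methyl on the core of compound 1 brings an at least 400-fold higher number from compound 1 to compound 4 (2.60 log units; beyond the scatter) in this assay. The earlier steps shown here concerned aromatic carbons only, whereas this one shows that the numbers also depend strongly on the group on a saturated chain carbon bound to an aromatic carbon, and that losing the hydroxy, 1 heavy atom, is enough for a large step. Compound 4 stands at a limit of the assay, not at a number: the limit of > 31600 nM in this assay, at which 1 of the 4 values shown sits.

On these data alone, how far the true value of compound 4 lies past that limit remains unknown, so the step has a lower bound only. Also open, as far as these compounds go, is whether an amine, a methyl ether or a carboxylic acid in place of the hydroxy would keep the low number of compound 1.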